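Isopropyl to isobutyl on a carbonyl: what to expect

A few compounds are considered here, and "the series" means these few. Any claim that something is new, unique, unknown or untested is made for them only; others in the source may bear on it.

Measured so far:
Compound 1, `Cc1c(OCCCCOc2ccc(C(=O)O)cc2)ccc(C(=O)CC(C)C)c1O`, gives 88%.
Compound 2, `Cc1cc(OCCCCOc2ccc(C(=O)CC(C)C)c(O)c2C)ccc1C(=O)O`, gives 93.3%.
Compound 3, `Cc1c(OCCCCOc2ccc(F)c(C(=O)O)c2)ccc(C(=O)C(C)C)c1O`, gives 74.1%.

These three compounds were tested in an assay on HEK293 cells for positive allosteric modulation of metabotropic glutamate receptor 2 (Rattus norvegicus), read by thallium flux, with a stated time of 2.5 min; on this read-out higher numbers stand for larger maximal responses and lower numbers for smaller maximal responses. Compound 3 stands lowest of the three: its number lies beyond the usual scatter below both compound 1 and compound 2, so the gap is real and not noise. Compound 4, `Cc1c(OCCCCOc2ccc(F)c(C(=O)O)c2)ccc(C(=O)CC(C)C)c1O`, has not yet been measured. It is compound 3 with one change: isobutyl in place of isopropyl on a carbonyl carbon.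

Among the compounds with values here, only one measured step joins two compounds that differ in a single place, a number 5.3 percentage points higher from compound 1 to compound 2 (within the scatter), and it concerns a methyl on an aromatic carbon, not the carbonyl substituent, so it says nothing directly about the change at hand. What the numbers do show is that compound 1 and compound 2, both carrying isobutyl on the carbonyl, sit higher than compound 3, which carries isopropyl; yet those two also differ from compound 3 in the fluorine and in where the carboxylic acid sits, so the comparison is not clean. On that weak footing a modest rise is expected, a number 7.9 percentage points higher from compound 3 to compound 4 (within the scatter), though a result within the scatter would not surprise. The estimate for compound 4 is therefore 82%, expected to fall between 66% and 96%.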

Compound 4, largest response reached (reported as percent of maximum), in percent of the reference or control that the assay uses: 84.5%
Beside the measured number, compound 4's estimate is 2.5 percentage points below it; measured number inside the range.
By their numbers in this assay, from the lowest: compound 3; then compounds 4, 1 and 2 (each within the scatter of the next).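

In this assay, within the data shown here, the change from isopropyl to isobutyl on a carbonyl carbon can now be read on its own for the first time, and the step is modest but real: a number 10.4 percentage points higher from compound 3 to compound 4 (beyond the scatter). With isobutyl held in place, changing the aryl group on the oxygen leaves the number within the scatter, both for 3-carboxy-4-fluorophenyl against 4-carboxyphenyl, a number 3.5 percentage points lower from compound 1 to compound 4 (within the scatter), and for 3-carboxy-4-fluorophenyl against 4-carboxy-3-methylphenyl, a number 8.8 percentage points lower from compound 2 to compound 4 (within the scatter). Compound 4 keeps the 3-carboxy-4-fluorophenyl group of compound 3, so among these four compounds the low standing of compound 3 goes with its isopropyl and not with that aryl group.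

Nothing at hand explains why this small change in the carbonyl substituent shifts the maximal response. On these data alone, only two carbonyl substituents are compared here, so it remains open whether a longer chain such as pentyl or a ring such as cyclopropyl at the same place would extend the rise or reverse it, and whether the step would keep its size with the 4-carboxyphenyl group.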